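Hydroxy in place of bromo on the anilino series

The source may hold more compounds than are shown below. What is called first, only, known or untested is meant among the compounds shown, and "the series" means these compounds.

For the measured compounds named here, in a functional assay on HL-60 cells (Homo sapiens) for cytotoxicity, read by MTT assay, with a stated time of 48 h (a lower number here means a stronger inhibitor, a higher number a weaker inhibitor), compound 1 (`COc1ccc(Nc2nc(-c3cccc(F)c3)nc3ccc(F)cc23)cc1`) gives 38600 nM, the only number. Compound 2 (`Fc1ccc(Nc2nc(-c3cccc(F)c3)nc3ccc(F)cc23)cc1`) gives only a limit, > 50000 nM. Compound 3 (`Fc1cccc(-c2nc(Nc3ccc(Br)cc3)c3cc(F)ccc3n2)c1`) also gives only a limit, > 50000 nM, so its true position is not known. The series thus presses against (the limit of > 50000 nM in this assay, at which 2 of the 3 values shown sit).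

Compound 4 (`Oc1ccc(Nc2nc(-c3cccc(F)c3)nc3ccc(F)cc23)cc1`) carries hydroxy in place of bromo on an aromatic carbon, para to a large group: hydroxy in place of bromo on an aromatic carbon.

Going by the values given here, three measured steps bear on this change. Two start from methoxy at the same place: an at least 1.2-fold higher number from compound 1 to compound 2 (0.11 log units; that floor lies within the scatter), and an at least 1.2-fold higher number from compound 1 to compound 3 (0.11 log units; that floor lies within the scatter). Both are floors, so neither gives a true size. Between the two halogens there is a step that the two limits leave unreadable from compound 2 to compound 3.

Among the compounds with values here, no measured step has hydroxy as a partner. The expectation rests on compound 1 at 38600 nM, which carries methoxy where compound 4 carries hydroxy. A modest move toward a lower number is therefore expected, and a reading at the limit remains quite possible. The expected size is an at least 1.4-fold lower number from compound 3 to compound 4 (0.15 log units; that floor lies within the scatter).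

Compound 4 is estimated at 35000 nM, with an expected range of 12000 nM to 70000 nM.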

Compound 4, half-maximal inhibitory concentration: > 50000 nM
Compound 4: no number, only a limit (the forecaster's own chance of this, stated with the estimate: 40%); at least 1.4-fold (0.15 log units) between middle value and limit.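

In this assay, hydroxy on an aromatic carbon para to a large group joins fluoro and bromo in giving only a limit, so among the groups shown at this place only methoxy gives a number. Hydrogen in place of methyl on the oxygen gives an at least 1.2-fold higher number from compound 1 to compound 4 (0.11 log units; that floor lies within the scatter), which is a floor and not a true size, so even this closest pair does not show that the methyl matters. The steps linking hydroxy with bromo and with fluoro cannot be read, and the series sits more firmly against the limit of the assay: the limit of > 50000 nM in this assay, at which 3 of the 4 values shown sit.

As far as these compounds go, whether hydroxy, fluoro and bromo differ from one another at all stays open, since none of the three has a true position in this assay. Also open, from the compounds shown here alone, is how an amine, a carboxylic acid or a longer chain such as ethoxy would read at this place, and whether any group here can move the series well clear of the limit.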